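The source may report more compounds than this note shows. Statements on the series, on what has been measured and on what is new or still open speak of the compounds shown alone.

Of the compounds shown here, three have been measured in an assay on HEK293 cells with Neuronal acetylcholine receptor; alpha4/beta2 (Homo sapiens) as the target, read by FLIPR and calcium flux; a lower number here means a smaller maximal response, a higher number a larger maximal response. Compound 3, `COc1ccc(N2CCCNCC2)cn1`, gives 88% in this assay. Within the data shown here, compound 2, `C=COc1cc(N2CCCNCC2)cnc1Br`, gives 80% in this assay, a number that lies within the usual scatter of the one for compound 3, so the two cannot be told apart. Compound 1, `C=COc1cncc(N2CCNCC2)c1`, gives 18% in this assay, a number far below both of the others, beyond the scatter. No two of these measured compounds differ in only one place, so no single structural change has yet been tied to a change in the read-out.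

Compound 4, `CCSc1ccc(N2CCCNCC2)cn1`, is the next to be measured. It differs from compound 3 in one place: ethylsulfanyl in place of methoxy on an aromatic carbon. Among the measured compounds shown here, nothing among the measured compounds shows what this particular swap does in this assay. Compound 4 is therefore expected to stay close to compound 3, with a step of a number 8 percentage points lower from compound 3 to compound 4 (within the scatter) that most likely lies within the scatter, in either direction. The estimate for compound 4 in this assay is 80%, with a range from 55% to 100%.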

Compound 4, largest response reached (reported as efficacy), in percent of the reference or control that the assay uses: 53%
Beside the measured number, compound 4's estimate is 27 percentage points above it; the measured number lies below the stated range.
By their numbers in this assay, from the lowest: compound 1; then compound 4; then compounds 2 and 3 (each within the scatter of the next).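

Among these compounds, this position, on an aromatic carbon next to the ring nitrogen, is the first place where a single change can be tied to a change in the read-out: in this assay, ethylsulfanyl in place of methoxy gives a number 35 percentage points lower from compound 3 to compound 4 (beyond the scatter). The two groups have the same hydrogen-bond donor and acceptor counts and neither carries a net charge, so these counts do not separate them; the visible differences are sulfur in place of oxygen and ethyl in place of methyl. Nothing available explains why the maximal response shifts with this swap.

From the compounds shown here alone, because both differences arrive together, their separate contributions remain open. Ethoxy or methylsulfanyl at this position would pull them apart, and the effect of an amine here is also open.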